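Replacing 3-chloro-4-fluorophenyl with 3-methoxyphenyl: notes on compound 4

The source may hold more compounds than are shown below. What is called first, only, known or untested is meant among the compounds shown, and "the series" means these compounds.

In a functional assay on HCT-116 cells (Homo sapiens) for antiproliferative activity, read by MTT assay (on this read-out higher numbers stand for weaker inhibition and lower numbers for stronger inhibition), compound 3 (`Cn1c(=O)c(=O)n(C2CCCC2)c2nc(N/N=C/c3ccc(F)c(Cl)c3)ncc21`) gives 9020 nM, within the scatter of compound 2 (`Cn1c(=O)c(=O)n(C2CCCC2)c2nc(N/N=C/c3ccc(Cl)cc3)ncc21`) at 9810 nM. Compound 1 (`Cn1c(=O)c(=O)n(C2CCCC2)c2nc(N/N=C/c3ccc(O)cc3)ncc21`) reads much higher at 72500 nM. Compound 4 (`COc1cccc(/C=N/Nc2ncc3c(n2)n(C2CCCC2)c(=O)c(=O)n3C)c1`) is the next case: 3-methoxyphenyl in place of 3-chloro-4-fluorophenyl on a carbon with a double bond to nitrogen. Going by the values given here, three measured steps bear on it. The halogen change gave a 1.1-fold lower number from compound 2 to compound 3 (0.04 log units; within the scatter), whereas leaving the 4-hydroxyphenyl gave a 7.4-fold lower number from compound 1 to compound 2 (0.87 log units; beyond the scatter) and an 8.0-fold lower number from compound 1 to compound 3 (0.91 log units; beyond the scatter). Among the compounds with values here, no measured compound carries a methoxy group, and the data only loosely bracket this change. A small move towards a higher number is expected, well short of the steps from the hydroxy compound. The step expected in this assay is a 1.8-fold higher number from compound 3 to compound 4 (0.25 log units; within the scatter). Compound 4 is expected at 16000 nM, with an estimated range of 6000 nM to 45000 nM.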

Compound 4, half-maximal inhibitory concentration: 45800 nM
Compound 4: the middle estimate sits 2.9-fold (0.46 log units) below what was measured; measured number outside the range, above it.
By their numbers in this assay, from the lowest: compounds 3 and 2 (each within the scatter of the next); then compounds 4 and 1 (each within the scatter of the next).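

In this assay, 3-methoxyphenyl on a carbon with a double bond to nitrogen does not hold the level of the halogen-bearing aryl groups, giving a 5.1-fold higher number from compound 3 to compound 4 (0.71 log units; beyond the scatter) and a 4.7-fold higher number from compound 2 to compound 4 (0.67 log units; beyond the scatter). Against the hydroxy compound the change gives a 1.6-fold lower number from compound 1 to compound 4 (0.20 log units; within the scatter), so both oxygen-bearing aryl compounds read alike, both halogen-bearing ones read alike, and no compound shown goes against this split. No measurement available explains the gap.

As far as these compounds go, whether the oxygen or the loss of halogen sets this level stays open. From the compounds shown here alone, how an amine or a carboxylic acid on the aromatic ring would read also stays open.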